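Aryl variation on the fused lactone core: HeLa cytotoxicity

The compounds below may be only part of what the source reports. "The series", "measured", "known", "first", "only" and "open" are said of these compounds alone.

Measured so far:
compound 1 `CCOC(=O)C12C(=O)OCC=C1COC2c1cccc(Cl)c1` > 1000000 nM
compound 2 `CCOC(=O)C12C(=O)OCC=C1COC2c1ccc(Cl)c(Cl)c1` 72400 nM
compound 3 `CCOC(=O)C12C(=O)OCC=C1COC2c1ccc(OC)c(OC)c1` 10000 nM

In a functional assay on HeLa cells (Homo sapiens) for cytotoxicity, read by MTT assay (a lower number here means a stronger inhibitor, a higher number a weaker inhibitor), compound 1 gives only a limit, > 1000000 nM, with no number behind it. Compound 2 reaches 72400 nM and compound 3 reaches 10000 nM. Among the compounds with values here, the one single-change step on record, an at least 13-fold lower number from compound 1 to compound 2 (1.14 log units; beyond the scatter), shows that altering the aryl ring can move the read-out strongly.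

Compound 4 `CCOC(=O)C12C(=O)OCC=C1COC2c1ccccn1` is not yet measured. It differs from compound 1 by pyridin-2-yl in place of 3-chlorophenyl on a saturated ring carbon. Within the data shown here, no measured step covers an exchange of the whole ring; the only related evidence is the aryl-substituent step above, which points to the ring mattering but not to a direction for a heteroaryl. Compound 4 is therefore expected near the limit, estimated at 500000 nM (50000 nM to 1000000 nM). That estimate means an expected step of an at least 2.0-fold lower number from compound 1 to compound 4 (0.30 log units; that floor lies within the scatter).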

Compound 4, half-maximal inhibitory concentration: 20700 nM
Compound 4: middle estimate off by 24-fold (1.38 log units), on the high side; measured number below the stated range.
By their numbers in this assay, from the lowest: compound 3; then compound 4; then compound 2. At a limit, above all of these: compound 1.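

At the saturated ring carbon, exchanging the whole ring, not only a substituent on it, also moves the read-out: pyridin-2-yl in place of 3-chlorophenyl gives an at least 48-fold lower number from compound 1 to compound 4 (1.68 log units; beyond the scatter) in this assay and a measured number without any chloro group. Going by these compounds, the true size of this step stays unknown because compound 1 has only a limit: the limit of > 1000000 nM in this assay, at which 1 of the 4 values shown sits.

Open, on these data alone, is whether pyridin-3-yl or unsubstituted phenyl at this carbon would read like compound 4. Also open, as far as these compounds go, is what an amine or a carboxylic acid on the aromatic ring would do.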